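Methoxyphenyl on the Ring Nitrogen of a Weak Antagonist

A few compounds are considered here, and "the series" means these few. Any claim that something is new, unique, unknown or untested is made for them only; others in the source may bear on it.

Compound 3 `CCCC(Oc1cnn(-c2cccc(Cl)c2)c1)c1ccc(C(=O)NCCC(=O)O)cc1` gives 16900 nM in a functional assay on cells for antagonist activity at Glucagon receptor (Homo sapiens), read by cAMP accumulation; a higher number here means a weaker inhibitor, a lower number a stronger inhibitor. Compound 1 `CCCC(Oc1cnn(-c2ccc(C(F)(F)F)cn2)c1)c1ccc(C(=O)NCCC(=O)O)cc1` gives 16400 nM there, and the two numbers lie within the scatter of each other, as a 1.0-fold higher number from compound 1 to compound 3 (0.01 log units; within the scatter) shows. Compound 2 `CCCC(Oc1cnn(-c2cccc(C)c2)c1)c1ccc(C(=O)NCCC(=O)O)cc1` returns only a limit of this assay, > 20900 nM. Compound 4 `CCCC(Oc1cnn(-c2ccc(OC)cc2)c1)c1ccc(C(=O)NCCC(=O)O)cc1` differs from compound 3 in one place: 4-methoxyphenyl in place of 3-chlorophenyl on an aromatic nitrogen. The swaps made so far on that nitrogen, an at least 1.2-fold higher number from compound 1 to compound 2 (0.10 log units; that floor lies within the scatter) and a 1.0-fold higher number from compound 1 to compound 3 (0.01 log units; within the scatter), together with an at least 1.2-fold lower number from compound 2 to compound 3 (0.09 log units; that floor lies within the scatter), all stayed within the scatter, so no step beyond the scatter is expected here either, in either direction. Compound 4 is therefore expected to give about 17000 nM, between 8000 nM and 40000 nM. For compound 4 this means an expected 1.0-fold higher number from compound 3 to compound 4 (0.00 log units; within the scatter).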

Compound 4, antagonist equilibrium constant: > 21300 nM
Compound 4: no number, only a limit (the forecaster's own chance of this, stated with the estimate: 40%); middle value at least 1.2-fold (0.09 log units) from the limit.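

Compound 4 returns only a limit in this assay, > 21300 nM. 4-Methoxyphenyl, the only group shown here that pairs a carbon-only ring with a hydrogen-bond acceptor, gives an at least 1.2-fold higher number from compound 3 to compound 4 (0.10 log units; that floor lies within the scatter) and an at least 1.2-fold higher number from compound 1 to compound 4 (0.11 log units; that floor lies within the scatter), so it brings no gain in strength at this ring nitrogen. The step between compound 2 and compound 4 cannot be read, as both values are limits.

Open, as far as these compounds go, is whether an amine or a carboxylic acid on this phenyl ring, or a longer chain in place of methoxy, would move the number beyond the scatter.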